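The source may report more compounds than this note shows. Statements on the series, on what has been measured and on what is new or still open speak of the compounds shown alone.

Compound 1 `COC(=O)c1ccc(-c2cnc(C(O)CCc3ccc(-c4ccccc4)cc3)o2)nc1` is the weakest of the three measured compounds in an assay for inhibition of Fatty-acid amide hydrolase 1 (Rattus norvegicus) (on this read-out higher numbers stand for weaker inhibition and lower numbers for stronger inhibition), where compound 1 gives 1100 nM. Compound 2 `N#Cc1cccc(-c2cnc(C(=O)CCc3ccc(-c4ccccc4)cc3)o2)n1` gives 2.9 nM in this assay, and compound 3 `COC(=O)c1ccc(-c2cnc(C(=O)CCc3ccc(COc4ccccc4)cc3)o2)nc1` gives 3.5 nM; both of these numbers lie far below that of compound 1, beyond the usual scatter. Compound 4 `O=C(O)c1ccc(-c2cnc(C(O)CCc3ccc(-c4ccccc4)cc3)o2)nc1` is the not yet measured analogue of compound 1. The change from compound 1 to compound 4 is hydrogen in place of methyl on an oxygen next to a carbonyl group. Among the measured compounds shown here, no pair of measured compounds differs by this change alone, so the measured data give no direct guide to its size or direction, and neither compound 2 nor compound 3 shares it. In that situation, compound 4 is expected to stay in the same weak range as compound 1, and the estimated step from compound 1 to compound 4 is a 2.3-fold higher number from compound 1 to compound 4 (0.36 log units; beyond the scatter), a modest move towards weaker inhibition. For compound 4 the estimated value in this assay is 2500 nM, with a range from 600 nM to 10000 nM.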

Compound 4, inhibition constant: 10000 nM
For compound 4 the middle estimate is 4.0-fold (0.60 log units) below the measured one; the range from low to high includes it.
By their numbers in this assay, from the lowest: compounds 2 and 3 (each within the scatter of the next); then compound 1; then compound 4.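

In this assay, the methoxycarbonyl to carboxy change gives a 9.1-fold higher number from compound 1 to compound 4 (0.96 log units; beyond the scatter), the only step shown at this position. It shows that this position is not indifferent to the change: removing the methyl from the oxygen moves compound 4 further towards weak inhibition, even though compound 1 already lay at the weak end of the series. Nothing measured here accounts for this step.

The compounds shown leave open how other groups in this place, such as a primary amide or an ethoxycarbonyl group, would compare with the methoxycarbonyl and carboxy groups. They also leave open whether the same change would produce a step of similar size and direction on a core carrying a ketone carbonyl instead of the hydroxyl group found in compound 1 and compound 4.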